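The source may hold more compounds than are shown below. What is called first, only, known or untested is meant among the compounds shown, and "the series" means these compounds.

The measured compounds:
Compound 1, `CSc1ccc2ccccc2n1`; in a functional assay on PC-3 cells (Homo sapiens) for cytotoxicity, read by MTT assay, with a stated time of 72 h (a higher number here means a weaker inhibitor of growth, a lower number a stronger inhibitor of growth), compound 1 gives > 100000 nM, which is a limit of the assay rather than a number.
Compound 2, `O=C1c2ccccc2C(=O)N1CS`; in this assay compound 2 gives > 100000 nM, likewise a limit of the assay.

Compound 2 therefore stands at the edge of what this assay can report, and it shares that position with compound 1, as the limit of > 100000 nM in this assay, at which 2 of the 2 values shown sit, shows. Compound 3, `O=C1c2ccccc2C(=O)N1C[SeH]`, has not yet been measured. It differs from compound 2 by one selenium atom in place of one sulfur atom, on a saturated chain carbon bound to an amide-type nitrogen in a ring. Among the compounds with values here, no step between two measured compounds has been recorded, so there is no measured precedent for an exchange of this kind. Since compound 2 sits at the reporting limit, a single-atom exchange of this sort is expected to leave the result within the scatter, or at most to bring it a little under the limit. Compound 3 is therefore expected to give 100000 nM in this assay, within a range from 30000 nM to 300000 nM. This amounts to an expected step of a number no higher from compound 2 to compound 3 (the limit leaves the size open).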

Compound 3, concentration for total growth inhibition: 9400 nM
Compound 3: the middle estimate sits 11-fold (1.03 log units) above what was measured, and the stated range ends above it.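

At this position, on a saturated chain carbon bound to an amide-type nitrogen in a ring, one selenium atom in place of one sulfur atom gives an at least 10-fold lower number from compound 2 to compound 3 (1.02 log units; beyond the scatter) in this assay. Compound 3 is thus the only compound shown that gives a number rather than a limit, so the earlier compounds gave no sign that a single-atom exchange here could bring the result within reach of this assay. Compound 2 gives only a limit, so the step does not fix the full size of the change: the limit of > 100000 nM in this assay, at which 2 of the 3 values shown sit.

The compounds shown leave open whether a longer chain carrying the selenium atom would keep this result. They also leave open how a methyl group on the selenium atom, or an amine in its place, would read in this assay.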